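Naphthalen-1-yl to thiophen-2-yl on the shared core

The compounds below may be only part of what the source reports. "The series", "measured", "known", "first", "only" and "open" are said of these compounds alone.

Of the compounds shown here, three have measured values so far. In a functional assay on MDA-MB-436 cells (Homo sapiens) for antiproliferative activity, read by MTT assay, with a stated time of 48 h (a lower number here means a stronger inhibitor, a higher number a weaker inhibitor), compound 1 `C=CS(=O)(=O)N1CCN(c2ncnc3ccc(-c4ccccc4)cc23)CC1` gives 23400 nM, compound 2 `C=CS(=O)(=O)N1CCN(c2ncnc3sc(-c4cccc5ccccc45)cc23)CC1` gives 28100 nM and compound 3 `C=CS(=O)(=O)N1CCN(c2ncnc3sc(-c4cnn(Cc5ccccc5)c4)cc23)CC1` gives 18300 nM. Compound 2 stands within the scatter of both others, so these three values do not separate. Among the measured compounds shown here, no measured pair differs in one place only, which leaves no single change with a measured step.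

The unmeasured compound 4 `C=CS(=O)(=O)N1CCN(c2ncnc3sc(-c4cccs4)cc23)CC1` has thiophen-2-yl in place of naphthalen-1-yl on an aromatic carbon, next to the ring sulfur, relative to compound 2: thiophen-2-yl in place of naphthalen-1-yl on an aromatic carbon.

Compound 3 carries another group at that place and, at 18300 nM, stays within the scatter of compound 2, so no step beyond the scatter is expected in this assay for this change. From the compounds shown here alone, the estimated step is a 1.3-fold lower number from compound 2 to compound 4 (0.13 log units; within the scatter), and its direction remains open. For compound 4 the expected value is 21000 nM, with an estimated range of 10000 nM to 42000 nM.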

Compound 4, half-maximal inhibitory concentration: 39000 nM
Beside the measured number, compound 4's estimate is 1.9-fold (0.27 log units) below it, and the stated range covers the measured number.
By their numbers in this assay, from the lowest: compounds 3, 1, 2 and 4 (each within the scatter of the next, the first and the last beyond it).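

In this assay, among the compounds shown here, the change from naphthalen-1-yl to thiophen-2-yl on this aromatic carbon, next to the ring sulfur, gives the first single-place step, a 1.4-fold higher number from compound 2 to compound 4 (0.14 log units; within the scatter), so replacing two six-membered aromatic rings of carbon only with one five-membered aromatic ring with 1 hetero atom does not separate the two compounds. Compound 3 at 18300 nM and compound 4 at 39000 nM now stand at the two ends of the order, and they are the only compounds shown that lie beyond the scatter of each other. Nothing available accounts for these values.

From the compounds shown here alone, whether an amine or a carboxylic acid at this place would give a step beyond the scatter remains open. Also open, going by these compounds, is whether thiophen-2-yl would give a similar step on the core of compound 1.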